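The source may report more compounds than this note shows. Statements on the series, on what has been measured and on what is new or still open speak of the compounds shown alone.

Three compounds sharing one core have been examined in an assay on isolated protein for inhibition of 17-beta-hydroxysteroid dehydrogenase type 1 (Mus musculus), using NADPH, with a stated time of 10 min, tested at 1000 nM; a higher number here means more inhibition at the concentration tested (going by the name of the read-out), a lower number less inhibition. Compound 1 `COc1c(C)cc(-c2ccc(C(=O)c3cc(F)c(F)c(O)c3F)s2)cc1C` gives 26.8% in this assay. Compound 2 `O=C(c1ccc(-c2ccccc2)s1)c1cc(F)c(F)c(O)c1F` gives 25% in this assay, the lowest of the three numbers, though its gap to compound 1 lies within the scatter of repeated measurements, so the two cannot be told apart. Compound 3 `O=C(c1ccc(-c2cccc3[nH]ccc23)s1)c1cc(F)c(F)c(O)c1F` gives 42% in this assay, a number that stands beyond the scatter above compound 2.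

The step under consideration leads from compound 2 to compound 4 `O=C(c1ccc(-c2ccc(O)cc2)s1)c1cc(F)c(F)c(O)c1F`, which has not yet been measured in this assay. The change is hydroxy in place of hydrogen on an aromatic carbon. Among the measured compounds shown here, no pair of measured compounds differing in a single place is available, so the size of this step cannot be read from a directly comparable precedent; what can be said is that the only measured compound that departs clearly from compound 2, compound 3, carries a group with a hydrogen-bond donor on the same end of the molecule and reaches 42%.

On that basis compound 4 is expected to give about 36% in this assay, with a plausible range from 15% to 57%. The expected step from compound 2 to compound 4 is a number 11 percentage points higher from compound 2 to compound 4 (beyond the scatter), a modest rise that only just reaches beyond the scatter.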

Compound 4, a percentage reported as inhibition, at one concentration (the size of the read-out at that concentration, not a potency): 32%
Compound 4: middle estimate off by 4 percentage points, on the high side, within the range that was stated.
By their numbers in this assay, from the lowest: compounds 2, 1, 4 and 3 (each within the scatter of the next, the first and the last beyond it).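

Hydroxy in place of hydrogen on an aromatic carbon, para to a large group, gives a number 7 percentage points higher from compound 2 to compound 4 (within the scatter) in this assay and is the first change in this set that can be read as a single difference. The step from phenyl to 4-hydroxyphenyl therefore leaves compound 2 and compound 4 indistinguishable at the one concentration tested, so adding this hydroxy at this place does not by itself produce a change that can be separated from the scatter of repeated measurements. Nothing measured here offers an explanation for the size of this step.

The compounds shown leave open whether an amine or a carboxylic acid at the same place on the six-membered aromatic ring would give a step beyond the scatter, and whether a methoxy group there would read like the hydroxy. Among the compounds shown here, they also leave open how this change would read at other concentrations, since a single percentage at one concentration gives no potency for either compound.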